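From hydroxymethyl to dimethylcarbamoyl on the shared core

The compounds below may be only part of what the source reports. "The series", "measured", "known", "first", "only" and "open" are said of these compounds alone.

Measured in an ADME assay on HEK293 cells (Homo sapiens) for cytotoxicity, with a stated time of 6 h (on this read-out higher numbers stand for lower toxicity in this test and lower numbers for higher toxicity in this test), so far:
Compound 1 (`CCCCCNc1nc(N)nc2ccccc12`) gives > 25000 nM as a limit
Compound 2 (`CCCCNc1nc(N)nc2cc(CO)ccc12`) gives > 18000 nM as a limit

Compound 2 stands at > 18000 nM in this assay as a limit of the assay and not as a number. Compound 3 (`CCCCNc1nc(N)nc2cc(C(=O)N(C)C)ccc12`) carries dimethylcarbamoyl in place of hydroxymethyl on an aromatic carbon. Going by the values given here, no measured step covers this change. The expectation rests on compound 2 with its limit (> 18000 nM) and on compound 1 with its own limit (> 25000 nM), since neither compound gives a number. The expected step (a step that the limit leaves unreadable from compound 2 to compound 3) lies within the usual scatter and has no firm direction. For compound 3 the estimated half-maximal cytotoxic concentration is 25000 nM in this assay with 9000 nM to 60000 nM as the expected range.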

Compound 3, half-maximal cytotoxic concentration: > 18000 nM
Compound 3: only a limit was reported; the forecaster's own chance of this, stated with the estimate: 70%; the middle value is on the limit's open side.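

Compound 2 and compound 3 both end at a limit of the assay in this assay, and no step can be read between them: the limit of > 18000 nM in this assay, at which 2 of the 3 values shown sit.

The compounds shown leave open whether dimethylcarbamoyl in place of hydroxymethyl on an aromatic carbon shifts the half-maximal cytotoxic concentration at all.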